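A few compounds are considered here, and "the series" means these few. Any claim that something is new, unique, unknown or untested is made for them only; others in the source may bear on it.

Measured compounds:
compound 1, `COc1cc(-c2cnn3cc(OC)c(C(C)C)nc23)ccn1`, 40%
compound 2, `COc1cc(-c2cnn3cc(OC)c(C4CCOC4)nc23)ccn1`, 29%
compound 3, `COc1cc(-c2cnn3cc(OC)c(C)nc23)ccn1`, 44%

In an ADME assay on microsomes from liver (Homo sapiens) for metabolic stability, with a stated time of 60 min, tested at 1 uM (on this read-out lower numbers stand for a less stable compound and higher numbers for a more stable compound), compound 1 stands second highest of the three; its gap to compound 3 is within the scatter, a number 4 percentage points higher from compound 1 to compound 3 (within the scatter), while compound 2 sits lower, a number 11 percentage points lower from compound 1 to compound 2 (beyond the scatter). Compound 4, `COc1cc(-c2cnn3cc(OC)c([C@H]4COC(C)(C)C4)nc23)ccn1`, carries a change at the same position: a group of 7 heavy atoms (6 carbon, 1 oxygen; one five-membered non-aromatic ring with 1 hetero atom) in place of a group of 3 heavy atoms (3 carbon; no ring), on an aromatic carbon. The closest measured step is the one from isopropyl to oxolan-3-yl, a number 11 percentage points lower from compound 1 to compound 2 (beyond the scatter), a modest drop; the step from oxolan-3-yl back to methyl, a number 15 percentage points higher from compound 2 to compound 3 (beyond the scatter), points the same way. The new ring in compound 4 is also a five-membered non-aromatic ring with one hetero atom, so a modest drop of similar size is expected, a number 10 percentage points lower from compound 1 to compound 4 (within the scatter). Compound 4 is therefore estimated at 30%, expected to fall between 18% and 45%.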

Compound 4, percent of the compound remaining: 21%
The estimate for compound 4 lay 9 percentage points above the measured number; the measured number falls inside the stated range.
By their numbers in this assay, from the lowest: compounds 4 and 2 (each within the scatter of the next); then compounds 1 and 3 (each within the scatter of the next).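

In this assay, the larger group on this aromatic carbon gives a clear loss against the smaller open groups: a number 19 percentage points lower from compound 1 to compound 4 (beyond the scatter), and a number 23 percentage points lower from compound 3 to compound 4 (beyond the scatter). Adding to the five-membered ring, however, has no readable effect: a number 8 percentage points lower from compound 2 to compound 4 (within the scatter), so both ring-bearing groups sit at the low end of this small set. No measurement here explains why these groups give lower numbers. On these data alone, whether cyclopentyl, with no ring oxygen, or an amine on this carbon would behave alike remains open. As far as these compounds go, the mirror-image form of compound 4 remains open too.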